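Swapping the aryl group on a dihydropyridine-type core

The source may hold more compounds than are shown below. What is called first, only, known or untested is meant among the compounds shown, and "the series" means these compounds.

Measured so far:
compound 1 `COC(=O)C1=C(C)N=C(C)/C(=C(\O)OC)C1c1cccc(Cl)c1Cl` — 19.1 nM
compound 2 `COC(=O)C1=C(C)N=C(C)/C(=C(\O)OC)C1c1cc(OC)c(OC)cc1OC` — 1000000 nM

In a functional assay (muscle tissue) with Cavia porcellus as the target (on this read-out lower numbers stand for an effect already at smaller amounts and higher numbers for an effect only at larger amounts of compound), compound 1 gives the lowest of the two numbers shown, and compound 2 sits a very long way behind it, far beyond the scatter of this assay. Compound 3 `COC(=O)C1=C(C)N=C(C)/C(=C(\O)OC)C1c1ccccc1F` has not yet been measured. It differs from compound 1 in one place: 2-fluorophenyl in place of 2,3-dichlorophenyl on a saturated ring carbon. Going by the values given here, no step between two measured compounds of this kind is available, so the size of this change can only be guessed from the two values given. Since the aryl group on that saturated ring carbon decides between compound 1 and compound 2 whether any effect is seen at all, some loss of potency from compound 1 to compound 3 is expected, moderate rather than complete, and beyond the scatter: a 7.9-fold higher number from compound 1 to compound 3 (0.90 log units; beyond the scatter). Compound 3 is therefore estimated at 150 nM, with a likely range from 30 nM to 800 nM.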

Compound 3, half-maximal effective concentration: 42.7 nM
Compound 3: middle estimate off by 3.5-fold (0.55 log units), on the high side; measured number inside the range.
By their numbers in this assay, from the lowest: compound 1; then compound 3; then compound 2.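

In this assay the change brings a 2.2-fold higher number from compound 1 to compound 3 (0.35 log units; beyond the scatter) and that step is modest, although beyond the scatter. The aryl group on this saturated ring carbon can therefore be changed without losing the effect: 2-fluorophenyl, with a single fluorine and no chlorine, still gives a low number, so the two chlorines of 2,3-dichlorophenyl are not both required for it. No measurement available here explains the size of this step.

The methoxy-bearing aryl group of compound 2 gives a far higher number, but the compounds shown do not tell which of its methoxy groups matters. Also open, on these data alone, is what this position would give with a plain phenyl group, or with a phenyl group carrying a nitro group or a trifluoromethyl group.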